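Aryl substituent exchange from compound 3 to compound 4

The source may report more compounds than this note shows. Statements on the series, on what has been measured and on what is new or still open speak of the compounds shown alone.

Three measured compounds share one core and differ only in the group on the aromatic ring. Compound 1 `Clc1ccccc1C1Cc2nccn2C1` carries chloro, compound 2 `Fc1ccccc1C1Cc2nccn2C1` fluoro and compound 3 `COCc1ccccc1C1Cc2nccn2C1` methoxymethyl. In a functional assay on CHO cells for agonist activity at Alpha-1A adrenergic receptor (Homo sapiens), read by FLIPR and calcium flux (on this read-out lower numbers stand for smaller maximal responses and higher numbers for larger maximal responses), compound 1 gives 56%, compound 2 gives 63% and compound 3 gives 77%. Compound 3 stands highest of the three: a number 14 percentage points higher from compound 2 to compound 3 (beyond the scatter) and a number 21 percentage points higher from compound 1 to compound 3 (beyond the scatter), both beyond the scatter, whereas a number 7 percentage points higher from compound 1 to compound 2 (within the scatter), which is within it.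

Compound 4 `COc1ccccc1C1Cc2nccn2C1` is the next compound in the series. The change from compound 3 to compound 4 is methoxy in place of methoxymethyl on an aromatic carbon. Within the data shown here, no measured step exchanges methoxymethyl for another oxygen-bearing group, so the expectation rests on the two steps of a number 21 percentage points higher from compound 1 to compound 3 (beyond the scatter) and a number 14 percentage points higher from compound 2 to compound 3 (beyond the scatter), which place methoxymethyl above both halogens, and on the fact that methoxy, like methoxymethyl, carries a hydrogen-bond acceptor. The step from compound 3 to compound 4 is therefore expected to be small, a number 7 percentage points lower from compound 3 to compound 4 (within the scatter), with a modest fall the more likely direction than a rise. In this assay compound 4 is estimated at 70%, in a range from 55% to 85%.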

Compound 4, largest response reached (Emax), in percent of the reference or control that the assay uses: 82%
Compound 4: the middle estimate sits 12 percentage points below what was measured, and the stated range covers the measured number.
By their numbers in this assay, from the lowest: compounds 1 and 2 (each within the scatter of the next); then compounds 3 and 4 (each within the scatter of the next).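

In this assay the exchange at this place gives a number 5 percentage points higher from compound 3 to compound 4 (within the scatter) and so methoxymethyl and methoxy cannot be told apart on this read-out, even though methoxy has one heavy atom fewer. Methoxy also stands clear of both halogens, with a number 19 percentage points higher from compound 2 to compound 4 (beyond the scatter) and a number 26 percentage points higher from compound 1 to compound 4 (beyond the scatter) pointing the same way, so compounds 3 and 4, the two oxygen-bearing members, form an upper pair and compounds 1 and 2, the two halogen members, a lower pair, and no compound shown goes against this split. No measurement shown accounts for the split.

The compounds shown leave open whether an oxygen atom is needed at this aromatic carbon at all, since a plain methyl or ethyl group there would separate the oxygen atom from the chain length, and a hydroxyl would test the oxygen atom without its methyl. They also leave open whether the upper pair extends to a longer chain such as ethoxy or to an amine at this place.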